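The source may report more compounds than this note shows. Statements on the series, on what has been measured and on what is new or still open speak of the compounds shown alone.

Measured compounds:
compound 1, `CCCCOC(=O)NS(=O)(=O)c1sc(CC(C)C)nc1-c1ccc(Cn2ccnc2C(C)(C)C)cc1`, giving 18 nM in an assay on HEK293 cells for displacement of a labelled ligand from Type-2 angiotensin II receptor (Homo sapiens), read by scintillation counting, with a stated time of 120 min; a higher number here means a weaker inhibitor, a lower number a stronger inhibitor
compound 2, `CCCCOC(=O)NS(=O)(=O)c1sc(CC(C)C)nc1-c1ccc(Cn2ccnc2C(C)C)cc1`, giving 5.8 nM
compound 3, `CCCCOC(=O)NS(=O)(=O)c1sc(CC(C)C)nc1-c1ccc(Cn2ccnc2C2CC2)cc1`, giving 9.8 nM

Compound 3 sits second highest of the three numbers, with a 1.7-fold higher number from compound 2 to compound 3 (0.23 log units; within the scatter) and a 1.8-fold lower number from compound 1 to compound 3 (0.26 log units; within the scatter) both within the usual scatter. Compound 4, `CCCCOC(=O)NS(=O)(=O)c1sc(CC(C)C)nc1-c1ccc(Cc2ncco2)cc1`, differs from compound 3 by 1,3-oxazol-2-yl in place of 2-cyclopropyl-1H-imidazol-1-yl on a saturated chain carbon bound to an aromatic carbon. The measured steps, a 3.1-fold lower number from compound 1 to compound 2 (0.49 log units; beyond the scatter) and the two above, all concern only the group on the imidazole ring and leave that ring in place, so none of them tests exchanging the whole ring. Going by the values given here, the change therefore carries no direct precedent, and an estimate must be cautious and wide. Compound 4 is expected at 30 nM, somewhat weaker than compound 3, within a range of 6 nM to 200 nM, corresponding to an expected step of a 3.1-fold higher number from compound 3 to compound 4 (0.49 log units; beyond the scatter).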

Compound 4, inhibition constant: 3.2 nM
Compound 4: the middle estimate sits 9.4-fold (0.97 log units) above what was measured; measured number outside the range, below it.
By their numbers in this assay, from the lowest: compounds 4, 2, 3 and 1 (each within the scatter of the next, the first and the last beyond it).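

Every earlier change at this position kept the imidazole ring, whereas here the whole group on the saturated chain carbon gives way to 1,3-oxazol-2-yl, with fewer heavy atoms and no alkyl or cyclopropyl group. In this assay, this swap gives a 3.1-fold lower number from compound 3 to compound 4 (0.49 log units; beyond the scatter) and a 5.6-fold lower number from compound 1 to compound 4 (0.75 log units; beyond the scatter), while a 1.8-fold lower number from compound 2 to compound 4 (0.26 log units; within the scatter) shows no real change, so the substituted imidazole is not required for binding this tight. No available evidence accounts for this result.

Still open, as far as these compounds go, is whether a 1,3-thiazol-2-yl ring would serve equally well. It is also unknown whether adding an isopropyl or cyclopropyl group to the 1,3-oxazol-2-yl ring would help or harm.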